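The source may report more compounds than this note shows. Statements on the series, on what has been measured and on what is new or still open speak of the compounds shown alone.

Three compounds share one core and differ only in the group on a saturated chain carbon bound to a saturated ring carbon. Compound 1 `Cc1c(C)c2c(c(C)c1N)CC(C)(CSc1nccn1C)O2` carries a 1-methyl-1H-imidazol-2-yl on a sulfur, and in a functional assay on the whole organism with Mus musculus as the target (on this read-out lower numbers stand for an effect already at smaller amounts and higher numbers for an effect only at larger amounts of compound), compound 1 gives 37.1 mg/kg. Compound 2 `Cc1c(C)c2c(c(C)c1N)CC(C)(CSCCO)O2` carries a 2-hydroxyethyl on that sulfur instead. In this assay compound 2 reaches only a limit of the assay, > 50 mg/kg. Among the compounds with values here, the single measured step is an at least 1.3-fold higher number from compound 1 to compound 2 (0.12 log units; that floor lies within the scatter), and its floor lies within the usual scatter, so its true size stays open; where compound 2 stands is told by the limit of > 50 mg/kg in this assay, at which 1 of the 2 values shown sits. Compound 3 `Cc1c(C)c2c(c(C)c1N)CC(C)(Cn1ccnc1)O2` carries the change (1H-imidazol-1-yl in place of (2-hydroxyethyl)sulfanyl on a saturated chain carbon bound to a saturated ring carbon). A five-membered aromatic ring with two nitrogens thus returns, as in compound 1, yet without any sulfur. Within the data shown here, the only related step, an at least 1.3-fold higher number from compound 1 to compound 2 (0.12 log units; that floor lies within the scatter), points toward a lower number in this assay for compound 3, with its size uncertain. The estimate for compound 3 is 35 mg/kg, with a range from 15 mg/kg to 50 mg/kg, which means an expected step of an at least 1.4-fold lower number from compound 2 to compound 3 (0.15 log units; that floor lies within the scatter).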

Compound 3, dose for 50% inhibition: 25 mg/kg
Compound 3: the middle estimate sits 1.4-fold (0.15 log units) above what was measured; the range from low to high includes it.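

Taking out the sulfur and setting the five-membered aromatic ring straight on the saturated chain carbon brings no visible loss in this assay: the change from the (1-methyl-1H-imidazol-2-yl)sulfanyl group is a 1.5-fold lower number from compound 1 to compound 3 (0.17 log units; within the scatter), so these two compounds cannot be told apart, and sulfur is not needed for an effect at this place. The change from the open (2-hydroxyethyl)sulfanyl group, which has no ring, to the 1H-imidazol-1-yl group is an at least 2.0-fold lower number from compound 2 to compound 3 (0.30 log units; that floor lies within the scatter), and among these three compounds, the two that carry a ring give numbers while the one without a ring does not. That step is only a floor and its true size stays open, because compound 2 stands at a limit and not at a number: the limit of > 50 mg/kg in this assay, at which 1 of the 3 values shown sits.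

The compounds shown leave open whether a ring with nitrogens matters here, or whether a plain phenyl ring or an open-chain amine on the same saturated chain carbon would do as well. They also leave open how the 1H-imidazol-1-yl ring would fare in this assay if carried on a longer chain.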